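Swapping Benzyl for (Furan-2-yl)methyl on a Shared Core

The compounds below may be only part of what the source reports. "The series", "measured", "known", "first", "only" and "open" are said of these compounds alone.

Measured so far in a functional assay on Jurkat cells (Homo sapiens) for inhibition, read by CCK-8 assay, with a stated time of 48 h; a higher number here means a weaker inhibitor of growth, a lower number a stronger inhibitor of growth
- Compound 1 `Cc1ccccc1Nc1nc(Nc2cccnc2)ncc1Cl` (38600 nM)
- Compound 2 `Cc1ccccc1Nc1nc(Nc2ccccc2)ncc1Cl` (> 100000 nM, a limit)
- Compound 3 `Cc1ccccc1Nc1nc(NCc2ccccc2)ncc1Cl` (> 100000 nM, a limit)

Compound 3 has a limit and not a number (> 100000 nM). That places it at the limit of > 100000 nM in this assay, at which 2 of the 3 values shown sit, so any step starting from compound 3 has an uncertain size.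

Compound 4 (`Cc1ccccc1Nc1nc(NCc2ccco2)ncc1Cl`) keeps the same chain but carries furan-2-yl in place of phenyl on a saturated chain carbon bound to a nitrogen on an aromatic ring.

Within the data shown here, no measured step makes this exact change, so the guidance is indirect. Among the measured compounds shown here, compound 1, with pyridin-3-yl, is the only compound here with a real number. Replacing that ring gave an at least 2.5-fold higher number from compound 1 to compound 2 (0.41 log units; beyond the scatter) and also an at least 2.5-fold higher number from compound 1 to compound 3 (0.41 log units; beyond the scatter). Both sizes are minimum values, and the change between the other two compounds gives a step that the two limits leave unreadable from compound 2 to compound 3. Compound 1 suggests that a ring with a hetero atom can go with a lower number, but it is a single example on a different linkage. A modest move to a lower number is therefore expected in this assay, and another limit is quite possible.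

The expected change is modest (an at least 1.2-fold lower number from compound 3 to compound 4 (0.09 log units; that floor lies within the scatter)). For compound 4 the estimated value is 80000 nM, with an expected range from 30000 nM to 200000 nM.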

Compound 4, concentration for 50% growth inhibition: > 100000 nM
Compound 4 ended at the assay's limit; the forecaster's own chance of this, stated with the estimate: 60%; at least 1.2-fold (0.09 log units) between middle value and limit.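

Compound 4 joins the compounds that reach the limit of this assay: the limit of > 100000 nM in this assay, at which 3 of the 4 values shown sit.

The steps linking compound 4 to compound 2 and to compound 3 cannot be read, so furan-2-yl in place of phenyl on a saturated chain carbon bound to a nitrogen on an aromatic ring has no measurable size here. Among these compounds, the only readable step is an at least 2.5-fold higher number from compound 1 to compound 4 (0.41 log units; beyond the scatter), and it gives up pyridin-3-yl for (furan-2-yl)methyl. A ring holding a hetero atom is therefore not enough on its own to give a measured value, and pyridin-3-yl remains the only group shown that gives one.

From the compounds shown here alone, what remains open is whether the measured value of compound 1 depends on the pyridin-3-yl ring itself or on that ring sitting directly on the nitrogen, a question that a pyridin-3-ylmethyl group on the same nitrogen would help to separate. The compounds at the limit also leave unknown how far apart in strength they really are.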